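Removing the pyrimidinyl group from a sulfonamide

The source may hold more compounds than are shown below. What is called first, only, known or untested is meant among the compounds shown, and "the series" means these compounds.

Compound 1 `C(=C/c1ccccc1)\C(=N\Nc1nncc2ccccc12)c1ccccc1` (3.2 nM)
Compound 2 `O=S(=O)(Nc1ncccn1)c1ccc(Nc2nncc3ccccc23)cc1` (34 nM)

Both compounds were tested in a functional assay on SF-268 cells (Homo sapiens) for antiproliferative activity, read by sulforhodamine B assay, with a stated time of 72 h; on this read-out lower numbers stand for stronger inhibition and higher numbers for weaker inhibition; compound 2 holds the higher of the two numbers, and so the weaker inhibition. Its gap to compound 1 lies beyond the usual scatter, but the two differ in more than one place, so the gap cannot be pinned on any single group.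

Compound 3 `NS(=O)(=O)c1ccc(Nc2nncc3ccccc23)cc1` has not yet been measured. It differs from compound 2 by one change (hydrogen in place of pyrimidin-2-yl on a sulfonamide nitrogen), which puts hydrogen in place of pyrimidin-2-yl on a sulfonamide nitrogen.

Going by the values given here, no measured pair shows this change alone, so any forecast is uncertain, and the starting point can only be compound 2 (34 nM). A small rise in the number is expected, perhaps no larger than the scatter, though a fall cannot be excluded. The expected step is modest (a 1.8-fold higher number from compound 2 to compound 3 (0.25 log units; within the scatter)). The estimate for compound 3 is 60 nM, with an expected range from 12 nM to 300 nM.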

Compound 3, half-maximal inhibitory concentration: 33 nM
Compound 3: middle estimate off by 1.8-fold (0.26 log units), on the high side, and the stated range covers the measured number.
By their numbers in this assay, from the lowest: compound 1; then compounds 3 and 2 (each within the scatter of the next).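

Replacing pyrimidin-2-yl with hydrogen on the sulfonamide nitrogen gives a 1.0-fold lower number from compound 2 to compound 3 (0.01 log units; within the scatter) in this assay, so compound 2 and compound 3 cannot be told apart on this read-out. For this pair, a whole six-membered aromatic ring with 2 hetero atoms can therefore leave this place without any detectable effect on the number, and the ring is not needed to hold antiproliferative activity at this level. No measurement is available that explains why the two compounds match.

This single pair does not show whether the sulfonamide nitrogen accepts any group equally well, as a methyl group, an acetyl group or a longer chain could give quite different numbers there. It also leaves open whether the sulfonamide itself matters, a question that a carboxylic acid or an amine in its place would begin to answer.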